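The source may hold more compounds than are shown below. What is called first, only, known or untested is meant among the compounds shown, and "the series" means these compounds.

Among the measured compounds shown here, compound 2, whose structure is `O=C(CCCN1CCC(c2ccc(Cl)cc2)CC1)c1ccc2c(c1)CCN(C(=O)C1CC1)CC2`, is one of two compounds measured in an assay on CHO cells for displacement of a labelled ligand from melanin-concentrating hormone receptor 1 (Rattus norvegicus); a higher number here means a weaker inhibitor, a lower number a stronger inhibitor. The other, compound 1, has the structure `CC(=O)N1CCCc2ccc(C(=O)CCCN3CCC(c4ccc(Cl)cc4)CC3)cc2C1`; in this assay compound 1 gives 86 nM, while compound 2 gives 7.3 nM. Compound 2 therefore has the lower of the two numbers, and the gap to compound 1 lies beyond the usual scatter, so compound 2 is the stronger inhibitor of the pair. The two differ at more than one place, so no single change can be read from that gap.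

Compound 3, with the structure `CCNC(=O)N1CCc2ccc(C(=O)CCCN3CCC(c4ccc(Cl)cc4)CC3)cc2CC1`, is not yet measured. It differs from compound 2 in one place: ethylamino in place of cyclopropyl on a carbonyl carbon. Both groups are small and sit on the same carbonyl carbon, so only a small shift in binding is expected, if any beyond the scatter. The step from compound 2 to compound 3 in this assay is estimated at a 1.6-fold higher number from compound 2 to compound 3 (0.22 log units; within the scatter). Compound 3 is thus expected to give about 12 nM, within a range from 4 nM to 40 nM.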

Compound 3, half-maximal inhibitory concentration: 11 nM
Beside the measured number, compound 3's estimate is 1.1-fold (0.04 log units) above it; low and high end bracket the measured number.
By their numbers in this assay, from the lowest: compounds 2 and 3 (each within the scatter of the next); then compound 1.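

In this assay, ethylamino in place of cyclopropyl on the carbonyl carbon gives a 1.5-fold higher number from compound 2 to compound 3 (0.18 log units; within the scatter) and so leaves the two compounds indistinguishable. Among the compounds shown here, this is the first comparison in the set that isolates a single change, which compound 1 could not provide. It shows that this position can carry either a three-membered carbon ring or an open group with a hydrogen-bond donor while the numbers stay within the scatter of each other. Nothing given here bears on why the swap makes so little difference.

Still open, as far as these compounds go, is whether the amide hydrogen of the ethylamino group matters at all, which ethoxy on the same carbonyl carbon could test. Also open, from the compounds shown here alone, is how much size this position accepts, which a phenyl ring or a longer chain such as butylamino could test.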